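The source may report more compounds than this note shows. Statements on the series, on what has been measured and on what is new or still open speak of the compounds shown alone.

Of the compounds shown here, three built on one shared core have been measured for how strongly they switch on the receptor. Compound 1 `CC#C[C@@H](Cc1nnn[nH]1)c1ccc(OCc2ccc3scc(-c4cccnc4C)c3c2)cc1` gives 20 nM in a functional assay on cells for agonist activity at Free fatty acid receptor 1 (Rattus norvegicus), read by FLIPR and calcium flux; a higher number here means that more compound is needed for the effect, a lower number that less compound is needed. Compound 2 `CC#C[C@@H](Cc1nnn[nH]1)c1ccc(OCc2ccc3sc(F)c(-c4ccc(OCCOC)cc4C)c3c2)cc1` gives 24 nM in this assay, and compound 3 `CC#C[C@@H](Cc1nnn[nH]1)c1ccc(OCc2ccc3sc(C#N)c(-c4ccccc4C)c3c2)cc1` gives 19 nM. These three numbers all lie within the usual scatter of one another, so compound 1 stands level with compounds 2 and 3, and none of them can be called more or less potent than another.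

Compound 4 `CC#C[C@@H](Cc1nnn[nH]1)c1ccc(OCc2ccc3scc(-c4cncnc4C)c3c2)cc1` is not yet measured. It differs from compound 1 by a single change: 4-methylpyrimidin-5-yl in place of 2-methylpyridin-3-yl on an aromatic carbon. Among the measured compounds shown here, no pair of measured compounds differs in just one place, so no measured step can guide this one. A step of modest size, if any, is expected, and it is expected to stay within the scatter as a 1.4-fold higher number from compound 1 to compound 4 (0.15 log units; within the scatter). Compound 4 is estimated to give 28 nM, with a likely range from 10 nM to 80 nM.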

Compound 4, half-maximal effective concentration: 18 nM
Beside the measured number, compound 4's estimate is 1.6-fold (0.19 log units) above it; low and high end bracket the measured number.
By their numbers in this assay, from the lowest: compounds 4, 3, 1 and 2 (each within the scatter of the next).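

Among the compounds shown here, this is the first step in the set that changes only one place, and it shows how little this swap matters. In this assay, putting 4-methylpyrimidin-5-yl in place of 2-methylpyridin-3-yl, on the aromatic carbon two ring bonds from the ring sulfur, gives a 1.1-fold lower number from compound 1 to compound 4 (0.05 log units; within the scatter), so a second ring nitrogen here leaves the reading level with the first. Nothing available explains why the two rings read alike. Still open, as far as these compounds go, is what the methyl group contributes, which a plain pyrimidin-5-yl would test. A morpholine ring or a carboxylic acid on this ring could also read quite differently.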